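The source may report more compounds than this note shows. Statements on the series, on what has been measured and on what is new or still open speak of the compounds shown alone.

In a functional assay on RPMI-8226 cells (Homo sapiens) for inhibition, read by sulforhodamine B assay, with a stated time of 48 h (on this read-out lower numbers stand for stronger inhibition of growth and higher numbers for weaker inhibition of growth), compound 1 `COc1cc(-c2nn(-c3cccc(NC(=O)Nc4ccc(Cl)c(Cl)c4)c3)cc2-c2ccncc2)ccc1Cl` gives 3260 nM. Compound 2 `O=C(Nc1cccc(-n2cc(-c3ccncc3)c(-c3ccc(Cl)c(O)c3)n2)c1)Nc1ccc(Cl)c(Cl)c1` reads > 32500 nM, which is only a limit, the one shown in the limit of > 32500 nM in this assay, at which 1 of the 2 values shown sits. Among the measured compounds shown here, the single measured step, an at least 9.9-fold higher number from compound 1 to compound 2 (0.99 log units; beyond the scatter), concerns hydrogen in place of methyl on an oxygen. Compound 3 `O=C(Nc1cccc(-n2cc(-c3ccncc3)c(-c3ccc(Cl)c(O)c3)n2)c1)Nc1ccc(Cl)c(C(F)(F)F)c1` instead carries trifluoromethyl in place of chloro on an aromatic carbon, ortho to a chloro group (trifluoromethyl in place of chloro on an aromatic carbon). For the measured compounds named here, no measured step covers this change, so no step beyond the scatter is expected in this assay. The expected step is an at least 1.3-fold lower number from compound 2 to compound 3 (0.13 log units; that floor lies within the scatter). Compound 3 is estimated at 24000 nM, with an expected range of 7000 nM to 32500 nM.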

Compound 3, concentration for total growth inhibition: 2000 nM
Beside the measured number, compound 3's estimate is 12-fold (1.08 log units) above it; measured number outside the range, below it.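

In this assay, trifluoromethyl in place of chloro on an aromatic carbon, ortho to a chloro group, brings an at least 16-fold lower number from compound 2 to compound 3 (1.21 log units; beyond the scatter). The earlier step concerned only the methyl on the oxygen, whereas this one shows that the 3,4-dichlorophenyl end also moves the read-out while the hydrogen on that oxygen stays. The size of the step is only a floor, since the value for compound 2 is a limit: the limit of > 32500 nM in this assay, at which 1 of the 3 values shown sits.

On these data alone, whether a nitrile or a methyl at this position would give a similar number remains open. So does how trifluoromethyl here reads with the methyl back on the oxygen.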